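Aryl replacement on the shared core and efficacy

The source may report more compounds than this note shows. Statements on the series, on what has been measured and on what is new or still open speak of the compounds shown alone.

Compound 1 `NS(=O)(=O)c1ccc(-c2nc(C(c3ccc(F)cc3)c3ccc(F)cc3)sc2CC(=O)O)cc1` gives 80% in an in vitro functional assay on HEK285-7 cells for antagonist activity at prostaglandin D2 receptor 2 (Homo sapiens), read by BRET and beta-arrestin recruitment; on this read-out lower numbers stand for smaller maximal responses and higher numbers for larger maximal responses. Compound 2 `N#Cc1ccc(-c2nc(C(c3ccc(F)cc3)c3ccc(F)cc3)sc2CC(=O)O)cc1` gives 30% in this assay. Compound 3 `Nc1cc(-c2nc(C(c3ccc(F)cc3)c3ccc(F)cc3)sc2CC(=O)O)cc(F)n1` gives 30% in this assay.

Compound 3 stands level with compound 2 at the digits printed, the two together the lowest of the three numbers; the step of no change at the digits printed from compound 2 to compound 3 (within the scatter) is within the scatter. Compound 1 is the furthest, separated by a number 50 percentage points lower from compound 1 to compound 3 (beyond the scatter).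

Compound 4 `O=C(O)Cc1sc(C(c2ccc(F)cc2)c2ccc(F)cc2)nc1-c1ccoc1` differs from compound 3 in one place: furan-3-yl in place of 2-amino-6-fluoropyridin-4-yl on an aromatic carbon. Among the compounds with values here, two steps bear on this exchange of the aromatic group on the shared core. The steps of a number 50 percentage points lower from compound 1 to compound 2 (beyond the scatter) and a number 50 percentage points lower from compound 1 to compound 3 (beyond the scatter) are both large, and no change at the digits printed from compound 2 to compound 3 (within the scatter) shows that two different groups in this place give the same number. Within the data shown here, no measured compound carries a furan-3-yl, so the size of its effect is unknown. Since compound 3 already sits at the lower end of the series, the expected step of a number 5 percentage points higher from compound 3 to compound 4 (within the scatter) is small, likely within the scatter. For compound 4 the expected value in this assay is 35%, with a range from 15% to 60%.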

Compound 4, largest response reached (reported as efficacy), in percent of the reference or control that the assay uses: 80%
Beside the measured number, compound 4's estimate is 45 percentage points below it; measured number outside the range, above it.
By their numbers in this assay, from the lowest: compounds 2 and 3 (each within the scatter of the next); then compounds 1 and 4 (each within the scatter of the next).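

Exchanging the aromatic group at this place on the shared core can move the number in this assay sharply: furan-3-yl gives a number 50 percentage points higher from compound 3 to compound 4 (beyond the scatter) and a number 50 percentage points higher from compound 2 to compound 4 (beyond the scatter). It also gives no change at the digits printed from compound 1 to compound 4 (within the scatter), so among these compounds a high number needs neither a sulfamoyl group nor a six-membered aromatic ring, while compound 1 shows that such a ring does not by itself keep the number low as it does in compound 2 and compound 3. Nothing available here accounts for this split between the four groups.

As far as these compounds go, it remains open whether an unsubstituted phenyl or a thiophen-3-yl at this place would stand with compound 4 or with compound 2. From the compounds shown here alone, the effect of a methyl group on the furan-3-yl ring, or of moving to furan-2-yl, also remains open.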